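The source may hold more compounds than are shown below. What is called first, only, known or untested is meant among the compounds shown, and "the series" means these compounds.

Measured so far:
- compound 1, `CC/C(=C(/c1ccc(/C=C/C(=O)O)cc1)c1cc2ccccc2[nH]1)c1ccccc1C`, 33 nM
- compound 2, `CC/C(=C(/c1ccc(/C=C/C(=O)O)cc1)c1cc2ccccc2[nH]1)c1ccccc1C(F)(F)F`, 8 nM

Both compounds were tested in a functional assay on MCF7 cells (Homo sapiens) for inhibition; on this read-out higher numbers stand for weaker inhibition and lower numbers for stronger inhibition. On the numbers shown, compound 1 stands at the highest of the two values; its nearest neighbour is compound 2, reached by the step of a 4.1-fold lower number from compound 1 to compound 2 (0.62 log units; beyond the scatter), a trifluoromethyl in place of methyl on an aromatic carbon.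

The unmeasured compound 3 has the structure `CC/C(=C(/c1ccc(/C=C/C(=O)O)cc1)c1cc2ccccc2[nH]1)c1ccc(C(F)(F)F)cc1`. Its difference from compound 1 is 4-(trifluoromethyl)phenyl in place of 2-methylphenyl on a double-bonded chain carbon bound to a double-bonded chain carbon and a saturated chain carbon.

Going by the values given here, one measured step bears on this change: the step of a 4.1-fold lower number from compound 1 to compound 2 (0.62 log units; beyond the scatter), which also swapped a methyl for a trifluoromethyl but kept the group where it stood. Among the compounds with values here, compound 3 makes the same swap and in addition moves the group to a different carbon of the 4-(trifluoromethyl)phenyl ring, for which no measured step exists. The expectation is therefore a modest downward step, a 2.8-fold lower number from compound 1 to compound 3 (0.44 log units; beyond the scatter), in this assay, though less certain than the measured one. The estimated value of compound 3 is 12 nM, with a range from 4 nM to 40 nM.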

Compound 3, half-maximal inhibitory concentration: 139 nM
Compound 3: middle estimate off by 12-fold (1.06 log units), on the low side; measured number above the stated range.
By their numbers in this assay, from the lowest: compound 2; then compound 1; then compound 3.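

In this assay the phenyl ring on the double-bonded chain carbon proves sensitive to where its substituent sits, and not only to which substituent it carries: the step of a 17-fold higher number from compound 2 to compound 3 (1.24 log units; beyond the scatter) is the largest in this small set, although 2-(trifluoromethyl)phenyl and 4-(trifluoromethyl)phenyl differ only in where the trifluoromethyl group stands. Replacing 2-methylphenyl with 4-(trifluoromethyl)phenyl gives a 4.2-fold higher number from compound 1 to compound 3 (0.62 log units; beyond the scatter) and so runs opposite to the gain seen with 2-(trifluoromethyl)phenyl in compound 2, which means that trifluoromethyl does not lower the number wherever it stands on this ring. Nothing available here explains why the location of the group matters so much.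

The three compounds do not separate the effect of the location from that of the group itself in the methyl series, and a 4-methylphenyl group would allow that comparison with compound 1 and compound 3. On these data alone, it also remains open whether a chlorine atom or a methoxy group on this ring would follow the pattern of methyl or that of trifluoromethyl.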